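The source may hold more compounds than are shown below. What is called first, only, known or untested is meant among the compounds shown, and "the series" means these compounds.

Compound 3 `CCSCC1C2CCC(O2)C1C/C=C\CCCC(=O)O` gives 5400 nM in a functional assay on a cell-free system (plasma) for inhibition of thromboxane A2 receptor (Homo sapiens) (a lower number here means a stronger inhibitor, a higher number a weaker inhibitor), the highest number among the three measured compounds. Compound 1 `CSCSCC1C2CCC(O2)C1C/C=C\CCCC(=O)O` gives 700 nM in this assay, and compound 2 `O=C(O)CCC/C=C\CC1C2CCC(O2)C1CSCCCc1ccccc1` gives 5000 nM. Compound 4 `CCCCSCC1C2CCC(O2)C1C/C=C\CCCC(=O)O` differs from compound 3 by ethyl in place of hydrogen on a saturated chain carbon, two bonds along the chain from a sulfur. The step that bears on this change is a 1.1-fold higher number from compound 2 to compound 3 (0.03 log units; within the scatter), which exchanges a larger group for hydrogen at the same place with no shift beyond the scatter. The steps of a 7.1-fold higher number from compound 1 to compound 2 (0.85 log units; beyond the scatter) and a 7.7-fold higher number from compound 1 to compound 3 (0.89 log units; beyond the scatter) were modest, but they concern the saturated chain carbon bound to a sulfur rather than this place. A change of a 1.2-fold lower number from compound 3 to compound 4 (0.08 log units; within the scatter) in this assay is therefore expected, with the estimate for compound 4 at 4500 nM, between 1500 nM and 15000 nM.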

Compound 4, half-maximal inhibitory concentration: 1000 nM
Compound 4: the middle estimate sits 4.5-fold (0.65 log units) above what was measured; the measured number lies below the stated range.
By their numbers in this assay, from the lowest: compounds 1 and 4 (each within the scatter of the next); then compounds 2 and 3 (each within the scatter of the next).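

Lengthening ethylsulfanyl to butylsulfanyl gives a 5.4-fold lower number from compound 3 to compound 4 (0.73 log units; beyond the scatter) in this assay, so this place does respond to added chain, even though compound 2 and compound 3, with benzyl and hydrogen there, lie within the scatter of each other. Methyl in place of phenyl gives a 5.0-fold lower number from compound 2 to compound 4 (0.70 log units; beyond the scatter), and propyl in place of methylsulfanyl gives a 1.4-fold higher number from compound 1 to compound 4 (0.15 log units; within the scatter), so a plain butyl chain matches the methylsulfanyl compound. No measurement here explains these shifts. As far as these compounds go, whether a longer chain such as hexyl goes further, or an amine at the chain end is accepted, remains open.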